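A Ring Swap on the Shared Core

The source may hold more compounds than are shown below. What is called first, only, known or untested is meant among the compounds shown, and "the series" means these compounds.

Compound 1 `C=CNCc1cc(-c2c(C(=O)NCC)noc2-c2cc(C(C)C)c(O)cc2O)on1`: 43 nM
Compound 2 `CCNC(=O)c1cc(-c2c(C(=O)NCC)noc2-c2cc(C(C)C)c(O)cc2O)on1`: 43 nM

In a functional assay on A2780 cells (Homo sapiens) for inhibition (a higher number here means a weaker inhibitor, a lower number a stronger inhibitor), compound 1 gives 43 nM and compound 2 gives 43 nM; the step of no change at the digits printed from compound 1 to compound 2 (within the scatter) lies within the scatter, so compound 2 stands level with compound 1. Compound 3 `CCNC(=O)c1noc(-c2cc(C(C)C)c(O)cc2O)c1-c1cnn(C(C)C)c1` differs from compound 2 by 1-isopropyl-1H-pyrazol-4-yl in place of 3-(ethylcarbamoyl)-1,2-oxazol-5-yl on an aromatic carbon. Going by the values given here, the one measured step altered only a group on the ring that now leaves; no measured step exchanges that ring itself, so it bears on this change only loosely. A modest shift toward a weaker inhibitor is expected, a 1.6-fold higher number from compound 2 to compound 3 (0.21 log units; within the scatter). Compound 3 is estimated at 70 nM, between 20 nM and 250 nM.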

Compound 3, half-maximal inhibitory concentration: 21 nM
The estimate for compound 3 lay 3.3-fold (0.52 log units) above the measured number, and the stated range covers the measured number.
By their numbers in this assay, from the lowest: compound 3; then compounds 1 and 2 (each within the scatter of the next).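

In this assay, the earlier pair had changed only a group on the ring at this position, whereas replacing that ring itself with 1-isopropyl-1H-pyrazol-4-yl gives a 2.0-fold lower number from compound 2 to compound 3 (0.31 log units; beyond the scatter). Measured against the ring carrying (vinylamino)methyl, the same exchange gives a 2.0-fold lower number from compound 1 to compound 3 (0.31 log units; beyond the scatter), so neither 1,2-oxazol-5-yl group is required at this place for inhibition in these cells. Nothing measured here accounts for the shift.

From the compounds shown here alone, whether the shift depends on the isopropyl group or on the pyrazole ring stays open. A 1-methyl-1H-pyrazol-4-yl group or a phenyl ring in the same place would bear on that question.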